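Permeability notes on the shared core: hydroxyethyl to methyl amide

A few compounds are considered here, and "the series" means these few. Any claim that something is new, unique, unknown or untested is made for them only; others in the source may bear on it.

Measured in an ADME assay for permeability; a higher number here means that the compound crosses the layer faster, a lower number that the compound crosses the layer more slowly:
compound 1 `CNC(=O)c1cc(C(=O)NCCO)n([C@@H](C)c2ccccc2)n1`: 59 nm/s
compound 2 `CNC(=O)c1cc(C(=O)N[C@H]2CC[C@H](O)CC2)n([C@@H](C)c2ccccc2Cl)n1`: 100 nm/s

In this assay compound 1 gives 59 nm/s and compound 2 gives 100 nm/s; the two numbers lie within the usual scatter of one another, so no ranking between them can be drawn. Compound 3 `CNC(=O)c1cc(C(=O)NC)n([C@@H](C)c2ccccc2)n1` is not yet measured. It differs from compound 1 in one place: hydrogen in place of hydroxymethyl on a saturated chain carbon bound to an amide-type nitrogen. Among the compounds with values here, no measured pair shows this change, so its size is unknown here. In this assay a moderate rise beyond the scatter is expected, a step of a 2.5-fold higher number from compound 1 to compound 3 (0.41 log units; beyond the scatter). Compound 3 is therefore estimated at 150 nm/s, with a range from 70 nm/s to 350 nm/s.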

Compound 3, apparent permeability: 280 nm/s
Estimate against measurement, compound 3: 1.9-fold (0.27 log units) below; the range from low to high includes it.
By their numbers in this assay, from the lowest: compounds 1 and 2 (each within the scatter of the next); then compound 3.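

Hydrogen in place of hydroxymethyl on a saturated chain carbon bound to an amide-type nitrogen gives the first step beyond the scatter in this assay (a 4.7-fold higher number from compound 1 to compound 3 (0.68 log units; beyond the scatter)). This position therefore responds to the change from 2-hydroxyethyl to methyl, and the direction is upward. No available data explain the rise.

Going by these compounds, whether the step follows the hydroxyl or the chain length stays open. An ethyl or a 2-methoxyethyl group in the same place would separate the two.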